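A few compounds are considered here, and "the series" means these few. Any claim that something is new, unique, unknown or untested is made for them only; others in the source may bear on it.

Compound 1, `CCCCCC(=O)Nc1cc2nc(C3CCCCC3)[nH]c2cc1N1CCCC1`, gives > 100 ug/mL in an ADME assay on Vero cells (Chlorocebus sabaeus) for cytotoxicity, read by resazurin assay, with a stated time of 3 days; on this read-out higher numbers stand for weaker inhibition and lower numbers for stronger inhibition; this is a limit of the assay rather than a measured number.
Compound 2, `CCCCNC(=O)Nc1cc2nc(C3CCCCC3)[nH]c2cc1N(CC)CC`, gives > 100 ug/mL in this assay; this too is a limit, not a number.

Among the measured compounds shown here, neither compound therefore has a true value in this assay, and compound 2 stands where the only other measured compound also stands: the limit of > 100 ug/mL in this assay, at which 2 of the 2 values shown sit. For the measured compounds named here, nothing here separates the two, and no step between measured compounds can be drawn from them.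

Compound 3, `CCN(CC)c1cc2[nH]c(C3CCCCC3)nc2cc1NC(=O)c1cnccn1`, is the next compound. Compared with compound 2 the change is pyrazin-2-yl in place of butylamino on a carbonyl carbon. With both measured compounds sitting at the limit, there is nothing in the numbers that points to either weaker or stronger inhibition for this change. The expected step is a number no higher from compound 2 to compound 3 (the limit leaves the size open), which means none beyond the scatter. Compound 3 is therefore expected to sit near the same limit, estimated at 100 ug/mL, with a range from 40 ug/mL to 250 ug/mL, and most likely the assay will again report only a limit for it.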

Compound 3, half-maximal inhibitory concentration: > 100 ug/mL
Compound 3: only a limit was reported (the forecaster's own chance of this, stated with the estimate: 75%); the middle value lies on the limit itself.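

In this assay compound 3 gives > 100 ug/mL, again a limit of the assay and not a number. No step can be read from compound 2 to compound 3, and all the compounds shown share one position: the limit of > 100 ug/mL in this assay, at which 3 of the 3 values shown sit.

The compounds shown leave open how far each lies from that limit, and whether pyrazin-2-yl in place of butylamino changes the read-out at all.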